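Hydroxy to Methyl on the Aryl Imine of Compound 2

The source may report more compounds than this note shows. Statements on the series, on what has been measured and on what is new or still open speak of the compounds shown alone.

The series was tested in a functional assay on HepG2 cells (Homo sapiens) for cytotoxicity, read by sulforhodamine B assay, with a stated time of 24 h; on this read-out lower numbers stand for stronger inhibition and higher numbers for weaker inhibition. Compound 1 `N=c1oc2ccccc2cc1C(=O)N/N=C1\C(=O)Nc2ccc(S(=O)(=O)N3CCOCC3)cc21` gives 7820 nM in this assay. Compound 2 `O=C1Nc2ccc(S(=O)(=O)N3CCOCC3)cc2/C1=N/c1ccc(O)cc1` gives 10400 nM in this assay; this number and that of compound 1 lie within the scatter of each other, so the two compounds cannot be told apart on cytotoxicity.

Compound 3 `Cc1ccc(/N=C2\C(=O)Nc3ccc(S(=O)(=O)N4CCOCC4)cc32)cc1` has not been measured. It differs from compound 2 in one place: methyl in place of hydroxy on an aromatic carbon. Within the data shown here, no step between measured compounds describes this change, so there is nothing in the two measured values to anchor its direction. The author expects the step from compound 2 to compound 3 to stay within the scatter, a 1.2-fold lower number from compound 2 to compound 3 (0.06 log units; within the scatter), with no clear direction. Compound 3 is therefore estimated at 9000 nM in this assay, within a range from 3500 nM to 25000 nM.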

Compound 3, half-maximal inhibitory concentration: 12800 nM
The estimate for compound 3 lay 1.4-fold (0.15 log units) below the measured number; the measured number falls inside the stated range.
By their numbers in this assay, from the lowest: compounds 1, 2 and 3 (each within the scatter of the next).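

Among these compounds, compound 2 and compound 3 form the only pair here that differs in one place, and so give the first direct reading of this position, on an aromatic carbon para to a large group. In this assay, the change from 4-hydroxyphenyl to 4-methylphenyl gives a 1.2-fold higher number from compound 2 to compound 3 (0.09 log units; within the scatter), so the assay does not separate the two compounds, although methyl has neither of the hydrogen-bond donors or acceptors counted for hydroxy. No measurement is at hand that could explain this result.

From the compounds shown here alone, whether an amine, a carboxylic acid or a methoxy group at this place would give a step beyond the scatter remains open. So does whether a hydroxy-to-methyl change elsewhere on the shared core would behave in the same way.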